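A few compounds are considered here, and "the series" means these few. Any claim that something is new, unique, unknown or untested is made for them only; others in the source may bear on it.

For the measured compounds named here, compound 3 `Cc1ccc(C2=NNC(c3cn(-c4ccccc4)nc3-c3ccc(Cl)c(Cl)c3)C2)cc1` gives 48.4% in a functional assay on the whole organism (strain Wistar) for inhibition, with Rattus norvegicus as the target, read by paw edema, with stated times of 30 min and 120 min, at a dose of 50 mg/kg by the oral route (a lower number here means less inhibition, a higher number more inhibition at the dose given (going by the name of the read-out)), the lowest of the three numbers so far. Compound 1 `CCC(=O)N1N=C(c2ccc(C)cc2)CC1c1cn(-c2ccccc2)nc1-c1ccc(Cl)c(Cl)c1` gives 70.3% and compound 2 `CCC(=O)N1N=C(c2ccc(F)cc2)CC1c1cn(-c2ccccc2)nc1-c1ccc(Cl)c(Cl)c1` gives 75.6%. The nearest number to compound 3 belongs to compound 1, and the step between them, hydrogen in place of propanoyl on an amine nitrogen in a ring, was a number 21.9 percentage points lower from compound 1 to compound 3 (beyond the scatter).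

Compound 4 `Fc1ccc(C2=NNC(c3cn(-c4ccccc4)nc3-c3ccc(Cl)c(Cl)c3)C2)cc1` differs from compound 3 by fluoro in place of methyl on an aromatic carbon. Going by the values given here, the only measured step of this kind, a number 5.3 percentage points higher from compound 1 to compound 2 (within the scatter), bears directly on it and stayed within the scatter. No step beyond the scatter is therefore expected in this assay for compound 4 either. For compound 4 the estimate is 53%, ranging from 40% to 66%, which amounts to an expected step of a number 4.6 percentage points higher from compound 3 to compound 4 (within the scatter).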

Compound 4, a percentage reported as inhibition, in the whole organism at one dose (the size of the read-out at that dose, not a potency): 46.1%
For compound 4 the middle estimate is 6.9 percentage points above the measured one, within the range that was stated.
By their numbers in this assay, from the lowest: compounds 4 and 3 (each within the scatter of the next); then compounds 1 and 2 (each within the scatter of the next).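

On the core without the propanoyl, the change from 4-methylphenyl to 4-fluorophenyl gives a number 2.3 percentage points lower from compound 3 to compound 4 (within the scatter), so in this assay this change stays within the scatter on both cores: the same change on two cores in this assay, a number 5.3 percentage points higher (within the scatter) from compound 1 to compound 2 and a number 2.3 percentage points lower (within the scatter) from compound 3 to compound 4, 7.6 percentage points apart, within the scatter of two such steps. Replacing propanoyl with hydrogen on the amine nitrogen in the ring now also gives a number 29.5 percentage points lower from compound 2 to compound 4 (beyond the scatter). This step holds with either aromatic group: the same change on two cores in this assay, a number 21.9 percentage points lower (beyond the scatter) from compound 1 to compound 3 and a number 29.5 percentage points lower (beyond the scatter) from compound 2 to compound 4, 7.6 percentage points apart, within the scatter of two such steps.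

Still open, on these data alone, is whether a methoxy or a carboxylic acid on this aromatic carbon would move the number. Also open, as far as these compounds go, is whether an acetyl or a longer acyl chain on the ring nitrogen would match propanoyl.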